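A few compounds are considered here, and "the series" means these few. Any claim that something is new, unique, unknown or untested is made for them only; others in the source may bear on it.

Measured so far:
compound 1 `CC1(C)CCC(C)(C)c2cc(C(=O)c3ccc4cc(C(=O)O)ccc4c3)c(F)cc21` — 70%
compound 2 `CC1(C)CCC(C)(C)c2cc(C(O)c3ccc4cc(C(=O)O)ccc4c3)c(O)cc21` — 47%
compound 3 `Cc1cc2c(cc1C(O)c1ccc3cc(C(=O)O)ccc3c1)C(C)(C)CCC2(C)C` — 82%

All three share one core and a carboxylic acid on the bicyclic aromatic part; they differ at the linking carbon and at one aromatic carbon of the core. In an assay on isolated protein with retinoic acid receptor gamma (Homo sapiens) as the target (a higher number here means a larger maximal response, a lower number a smaller maximal response), compound 3 gives the highest of the three numbers. Its nearest neighbour is compound 1 at 70%, a gap beyond the scatter, and the furthest is compound 2 at 47%. Going by the values given here, the only single-point step among the measured compounds is a number 35 percentage points higher from compound 2 to compound 3 (beyond the scatter), a large rise.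

Compound 4 `CC1(C)CCC(C)(C)c2cc(C(O)c3ccc4cc(C(=O)O)ccc4c3)c(F)cc21` is not yet measured. Its change from compound 3 is fluoro in place of methyl on an aromatic carbon. Among the compounds with values here, no measured step covers fluoro against methyl at this position. Compound 1, which carries fluoro on the same aromatic carbon but a carbonyl linker instead of the carbinol, sits at 70%, below compound 3; since that pair differs in two places, it only points loosely. Compound 2 shows that a hydroxy at this carbon gives a much lower maximal response, so a small substituent other than methyl is expected to cost something in this assay. The expected step is a number 14 percentage points lower from compound 3 to compound 4 (beyond the scatter), a moderate fall, with compound 4 estimated at 68% (range 50% to 85%).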

Compound 4, largest response reached (reported as maximum), in percent of the reference or control that the assay uses: 70%
For compound 4 the middle estimate is 2 percentage points below the measured one; the range from low to high includes it.
By their numbers in this assay, from the lowest: compound 2; then compounds 1 and 4 (each within the scatter of the next); then compound 3.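

On the shared carbinol core, the aromatic carbon ortho to a large group now carries three different substituents, and all three can be compared directly in this assay. Fluoro does not match methyl here, with a number 12 percentage points lower from compound 3 to compound 4 (beyond the scatter), yet it retains much of what hydroxy loses, with a number 23 percentage points higher from compound 2 to compound 4 (beyond the scatter); the three groups therefore separate beyond the scatter, with methyl highest, fluoro intermediate and hydroxy lowest, and no compound shown goes against this order. With fluoro held constant, the carbonyl-linked compound 1 gives 70% and the carbinol-linked compound 4 gives 70%, two values within the scatter of each other, so this pair shows no separation between the two linkers, while the data offer no measured basis for explaining the substituent order.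

On these data alone, whether the same substituent order holds with the carbonyl linker remains open, since only the fluoro compounds allow that linker comparison. As far as these compounds go, how a chloro, methoxy, ethyl or amino group on this aromatic carbon would fall relative to methyl, fluoro and hydroxy also remains open.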